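Imidazole Replaces Chloropyrimidine on the Amide Carbonyl

The compounds below may be only part of what the source reports. "The series", "measured", "known", "first", "only" and "open" are said of these compounds alone.

Three compounds on one shared core were measured in a functional assay on A549 cells (Homo sapiens) for antiproliferative activity, read by MTT assay, with a stated time of 72 h; a higher number here means a weaker inhibitor, a lower number a stronger inhibitor. Compound 1 `COc1cc(N(C)C)c(NC(=O)c2ccncn2)cc1Nc1nccc(-c2cn(C)c3ccccc23)n1` gives 5160 nM. Compound 2 `COc1cc(N(C)C)c(NC(=O)c2ncccn2)cc1Nc1nccc(-c2cn(C)c3ccccc23)n1` gives 8640 nM. Compound 3 `COc1cc(N(C)C)c(NC(=O)c2ccnc(Cl)n2)cc1Nc1nccc(-c2cn(C)c3ccccc23)n1` gives 2840 nM; against compound 1 this lies within the scatter, against compound 2 beyond it.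

Compound 4 `COc1cc(N(C)C)c(NC(=O)c2c[nH]cn2)cc1Nc1nccc(-c2cn(C)c3ccccc23)n1` is not yet measured. It differs from compound 3 in one place: 1H-imidazol-4-yl in place of 2-chloropyrimidin-4-yl on a carbonyl carbon. For the measured compounds named here, the steps that bear on this exchange the ring on the carbonyl carbon: a 1.7-fold higher number from compound 1 to compound 2 (0.22 log units; within the scatter) and a 3.0-fold lower number from compound 2 to compound 3 (0.48 log units; beyond the scatter), while a 1.8-fold lower number from compound 1 to compound 3 (0.26 log units; within the scatter) shows that the chloro by itself moved the number within the scatter. None of these steps brings in a five-membered ring or a hydrogen-bond donor, so the direction rests on thin ground. Compound 4 is expected to give a somewhat higher number in this assay, a 1.8-fold higher number from compound 3 to compound 4 (0.25 log units; within the scatter). The estimate for compound 4 is 5000 nM, with a range from 2000 nM to 13000 nM.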

Compound 4, half-maximal inhibitory concentration: 3560 nM
Beside the measured number, compound 4's estimate is 1.4-fold (0.15 log units) above it, within the range that was stated.
By their numbers in this assay, from the lowest: compounds 3, 4, 1 and 2 (each within the scatter of the next, the first and the last beyond it).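

In this assay, for the compounds shown here, the exchange on the carbonyl carbon brings in a five-membered aromatic ring with a hydrogen-bond donor for the first time, and the number stays within the scatter on both sides: a 1.3-fold higher number from compound 3 to compound 4 (0.10 log units; within the scatter), and a 1.4-fold lower number from compound 1 to compound 4 (0.16 log units; within the scatter). Only against pyrimidin-2-yl does 1H-imidazol-4-yl stand beyond the scatter, with a 2.4-fold lower number from compound 2 to compound 4 (0.39 log units; beyond the scatter), so at this position neither a six-membered ring nor the chloro is required for a number at this level. No measurement bears on what lies behind these steps.

The compounds shown do not separate the change in ring size from the hydrogen-bond donor that enters with it. Going by these compounds, it also remains open how a ring on the carbonyl carbon carrying an amine or a carboxylic acid would read in this assay.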